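Nitro for trifluoromethyl on the pyridine of compound 3

The source may report more compounds than this note shows. Statements on the series, on what has been measured and on what is new or still open speak of the compounds shown alone.

Three compounds share one core and differ only in the substituent on the aromatic ring. Compound 1 `Brc1ccc(OC[C@@H]2CCN2)cn1` gives 0.021 nM in an assay on brain for binding affinity to Neuronal acetylcholine receptor; alpha4/beta2 (Rattus norvegicus), read by radioligand binding (on this read-out higher numbers stand for weaker inhibition and lower numbers for stronger inhibition), compound 2 `C=Cc1ccc(OC[C@@H]2CCN2)cn1` gives 1.25 nM, and compound 3 `FC(F)(F)c1cncc(OC[C@@H]2CCN2)c1` gives 0.49 nM. Compound 3 thus holds the second highest of the three numbers, nearest to compound 2 and furthest from compound 1. Among the compounds with values here, the single step between neighbours, a 60-fold higher number from compound 1 to compound 2 (1.77 log units; beyond the scatter), shows that a change of the ring substituent can move the number a long way.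

Compound 4 `O=[N+]([O-])c1cncc(OC[C@@H]2CCN2)c1` differs from compound 3 by nitro in place of trifluoromethyl on an aromatic carbon. Within the data shown here, no measured step covers this exchange, and the one step known sits on a different place of the ring, so it gives only a sense of the possible size, not of the direction. The step from compound 3 to compound 4 is therefore expected to be small, a 1.6-fold higher number from compound 3 to compound 4 (0.21 log units; within the scatter), with a wide margin either way. For compound 4 the expected value in this assay is 0.8 nM, with a range from 0.15 nM to 5 nM.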

Compound 4, inhibition constant: 0.33 nM
Beside the measured number, compound 4's estimate is 2.4-fold (0.38 log units) above it, and the stated range covers the measured number.
By their numbers in this assay, from the lowest: compound 1; then compounds 4 and 3 (each within the scatter of the next); then compound 2.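

In this assay the exchange gives a 1.5-fold lower number from compound 3 to compound 4 (0.17 log units; within the scatter) and so does not tell nitro and trifluoromethyl apart at this aromatic carbon, two atoms from the ring nitrogen. Trifluoromethyl, with 0 hydrogen-bond acceptors, gives way here to nitro, with 2, and the step stays within the scatter, so in this pair the acceptor count goes with no readable shift in the number. No measured property is at hand to explain why the two groups read alike.

On these data alone, whether an amine, a carboxylic acid or a nitrile at this carbon would stay close to these two remains open. Also open, as far as these compounds go, is how bromo and vinyl would read here, as those groups stand at another place on the ring in compound 1 and compound 2.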